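The source may report more compounds than this note shows. Statements on the series, on what has been measured and on what is new or still open speak of the compounds shown alone.

In an ADME assay on Huh-7 cells (Homo sapiens) for cytotoxicity (a lower number here means a stronger inhibitor, a higher number a weaker inhibitor), three compounds have been measured so far:
compound 1 `CN(c1cc2ncc(=O)[nH]c2cc1NC(=S)NC(=O)c1cccc(C(F)(F)F)c1)C1CCCCC1`, 31500 nM
compound 2 `CSCCc1nc2cc(N(C)C3CCCCC3)c(Nc3nc(-c4ccccc4)cs3)cc2[nH]c1=O`, 86000 nM
compound 3 `CN(c1ccccc1)c1cc2ncc(=O)[nH]c2cc1Nc1nc(-c2ccccc2)cs1`, 15900 nM

Compound 3 shows the lowest of the three numbers, but compound 1 lies within the scatter of it, so these two cannot be ordered; only compound 2 stands clearly higher. Compound 4 `CCN(CC)c1cc2ncc(=O)[nH]c2cc1Nc1nc(-c2ccccc2)cs1` has not yet been tested in this assay. It differs from compound 3 in one place: diethylamino in place of methyl(phenyl)amino on an aromatic carbon. Going by the values given here, no measured pair covers this change, so the expectation rests on the spread of the three numbers alone. Compound 4 is expected to give a somewhat higher number, a step of a 1.6-fold higher number from compound 3 to compound 4 (0.20 log units; within the scatter), though one that may well stay inside the scatter. The estimate for compound 4 is 25000 nM, with a range from 8000 nM to 80000 nM.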

Compound 4, half-maximal inhibitory concentration: 22800 nM
Compound 4: middle estimate off by 1.1-fold (0.04 log units), on the high side; the measured number falls inside the stated range.
By their numbers in this assay, from the lowest: compounds 3, 4 and 1 (each within the scatter of the next); then compound 2.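

In this assay the change from methyl(phenyl)amino to diethylamino on this aromatic carbon gives a 1.4-fold higher number from compound 3 to compound 4 (0.16 log units; within the scatter) and so does not separate the two compounds. For this pair, a group with no ring takes the place of one carrying a six-membered aromatic ring of carbon only, and the numbers stay within the scatter of each other. Nothing measured here offers an explanation for this result. From the compounds shown here alone, it remains open whether a cyclic amine such as morpholine or piperazine would also stay within the scatter at this position. Whether a carboxylic acid on the amine's chain would do so is equally unresolved.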